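The compounds below may be only part of what the source reports. "The series", "measured", "known", "first", "only" and "open" are said of these compounds alone.

Three compounds share one core and differ only in the group carried on an amine nitrogen. In an assay on CHO cells for binding affinity to 5-hydroxytryptamine receptor 1B (Homo sapiens) (a higher number here means a weaker inhibitor, a lower number a stronger inhibitor), compound 1 `OCCC(NC1CCN(CCCc2c[nH]c3ccc(-n4cnnc4)cc23)CC1)c1ccccc1` gives 150 nM. Compound 2 `COC[C@H](NC1CCN(CCCc2c[nH]c3ccc(-n4cnnc4)cc23)CC1)c1ccccc1` gives 210 nM in this assay, and compound 3 `CC(=O)Nc1ccc([C@@H](C)NC2CCN(CCCc3c[nH]c4ccc(-n5cnnc5)cc34)CC2)cc1` gives 350 nM. Compound 2 thus stands second highest of the three numbers, with compound 1 nearest and compound 3 furthest, and both of those gaps lie within the usual scatter. The unmeasured compound 4 `CC(CO)(NC1CCN(CCCc2c[nH]c3ccc(-n4cnnc4)cc23)CC1)c1ccccc1` differs from compound 2 as follows: 1-(hydroxymethyl)-1-phenylethyl in place of 2-methoxy-1-phenylethyl on an amine nitrogen. Among the measured steps, the ones that bear on this change are the exchanges of the same group at the same place: a 1.4-fold higher number from compound 1 to compound 2 (0.15 log units; within the scatter), a 1.7-fold higher number from compound 2 to compound 3 (0.22 log units; within the scatter), and the only one reaching beyond the scatter, a 2.3-fold higher number from compound 1 to compound 3 (0.37 log units; beyond the scatter). Compound 1 already carries a hydroxyl on that group and sits close to compound 2, so only a small step, if any, is expected from compound 2 to compound 4 in this assay, namely a 1.0-fold higher number from compound 2 to compound 4 (0.02 log units; within the scatter). Compound 4 is therefore estimated at 220 nM, within a range from 100 nM to 500 nM.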

Compound 4, half-maximal inhibitory concentration: 98 nM
Estimate against measurement, compound 4: 2.2-fold (0.35 log units) above; the measured number lies below the stated range.
By their numbers in this assay, from the lowest: compounds 4, 1, 2 and 3 (each within the scatter of the next, the first and the last beyond it).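

Exchanging 2-methoxy-1-phenylethyl for 1-(hydroxymethyl)-1-phenylethyl keeps the same atoms, yet this assay shows a 2.1-fold lower number from compound 2 to compound 4 (0.33 log units; beyond the scatter) beyond the scatter, so this amine nitrogen is sensitive to how those atoms are joined, not only to which atoms are present. The widest gap among these groups is now a 3.6-fold lower number from compound 3 to compound 4 (0.55 log units; beyond the scatter) while a 1.5-fold lower number from compound 1 to compound 4 (0.18 log units; within the scatter) stays within the scatter, so the two groups carrying a hydroxyl cannot be ranked against each other. No measurement here offers a reason for these differences.

The compounds shown do not separate the effect of the free hydroxyl from that of the extra methyl on the carbon bearing the phenyl ring. On these data alone, it also remains open how an amine or a carboxylic acid in place of that hydroxyl would compare.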